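Swapping nitro for fluoro on a sulfonyl-bearing phenyl ring

The source may report more compounds than this note shows. Statements on the series, on what has been measured and on what is new or still open speak of the compounds shown alone.

Three compounds have been measured in an ADME assay on HEK-293T cells (Homo sapiens) for cytotoxicity, read by MTT assay, with a stated time of 24 h; a higher number here means that more compound is tolerated, a lower number that less compound is tolerated:

compound 1, `O=[N+]([O-])c1ccc(S(=O)(=O)n2c(-c3cn(-c4ccccc4)nc3-c3ccc(F)cc3)nc3ccccc32)cc1`, gives 189000 nM
compound 2, `O=S(=O)(c1ccc(F)cc1)n1c(-c2cn(-c3ccccc3)nc2-c2ccc(F)cc2)nc2ccccc21`, gives 218000 nM
compound 3, `O=[N+]([O-])c1ccc(S(=O)(=O)n2c(-c3cn(-c4ccccc4)nc3-c3ccc(C(F)(F)F)cc3)nc3ccccc32)cc1`, gives 163000 nM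

Compound 1 and compound 2 share a core and differ in one place: fluoro in place of nitro on an aromatic carbon. That change made the step of a 1.2-fold higher number from compound 1 to compound 2 (0.06 log units; within the scatter), so the two values cannot be told apart. Compound 3 differs from compound 1 in another place: trifluoromethyl in place of fluoro on an aromatic carbon, which made the step of a 1.2-fold lower number from compound 1 to compound 3 (0.06 log units; within the scatter), again a step that cannot be told apart from no change. All three numbers in this assay therefore sit close together.

Compound 4, `O=S(=O)(c1ccc(F)cc1)n1c(-c2cn(-c3ccccc3)nc2-c2ccc(C(F)(F)F)cc2)nc2ccccc21`, has not yet been measured. It differs from compound 3 in this way: fluoro in place of nitro on an aromatic carbon. The place line reads the same, word for word, as for the change from compound 1 to compound 2, so this is the same change, made on the core of compound 3 rather than that of compound 1. Because the earlier instance gave a 1.2-fold higher number from compound 1 to compound 2 (0.06 log units; within the scatter), the expectation is a step of similar size, a 1.1-fold higher number from compound 3 to compound 4 (0.05 log units; within the scatter), which in practice means no detectable difference from compound 3. Going by the values given here, on that basis compound 4 is expected to give about 185000 nM in this assay, with a plausible range from 110000 nM to 310000 nM; this estimate rests on only one prior example of the change.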

Compound 4, half-maximal cytotoxic concentration: 157000 nM
Compound 4: middle estimate off by 1.2-fold (0.07 log units), on the high side; low and high end bracket the measured number.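

Made on a second core, the swap from nitro to fluoro gave a 1.0-fold lower number from compound 3 to compound 4 (0.02 log units; within the scatter), and set beside its earlier instance it shows no difference between the two cores: the same change on two cores in this assay, a 1.2-fold higher number (0.06 log units; within the scatter) from compound 1 to compound 2 and a 1.0-fold lower number (0.02 log units; within the scatter) from compound 3 to compound 4, 1.2-fold (0.08 log units) apart, within the scatter of two such steps

The swap from fluoro to trifluoromethyl can now be read on a second core as well, where it gave a 1.4-fold lower number from compound 2 to compound 4 (0.14 log units; within the scatter), and it too agrees with its earlier instance: the same change on two cores in this assay, a 1.2-fold lower number (0.06 log units; within the scatter) from compound 1 to compound 3 and a 1.4-fold lower number (0.14 log units; within the scatter) from compound 2 to compound 4, 1.2-fold (0.08 log units) apart, within the scatter of two such steps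

In this assay, going by these compounds alone, then, each change carries from one core to the other in the limited sense that its step stays within the scatter on both, but with only two cores per change and no step large enough to be told apart from no change, this does not show that either change has a real effect of a consistent size, or that the same would hold on further cores.

The compounds shown carry only nitro or fluoro on the sulfonyl-bearing ring and only fluoro or trifluoromethyl on the other substituted phenyl ring. On these data alone, it therefore remains open whether a quite different group in either place, such as an amine, a carboxylic acid or a longer carbon chain, would leave the numbers this close together.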